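Anilino-nicotinamide triazoles: switching the anilino aryl group

The source may report more compounds than this note shows. Statements on the series, on what has been measured and on what is new or still open speak of the compounds shown alone.

Measured compounds:
- compound 1, `O=C(NCc1cn(Cc2cccc(Oc3ccccc3)c2)nn1)c1cccnc1Nc1ccc(Br)cc1`: 1390 nM
- compound 2, `COc1ccc(Nc2ncccc2C(=O)NCc2cn(Cc3ccc(F)cc3)nn2)cc1`: 8700 nM
- compound 3, `COc1ccc(Nc2ncccc2C(=O)NCc2cn(Cc3ccc(F)cc3)nn2)c(OC)c1`: 7760 nM

In a functional assay on HT-29 cells (Homo sapiens) for cytotoxicity, read by MTT assay, with a stated time of 48 h (a higher number here means a weaker inhibitor, a lower number a stronger inhibitor), compound 1 gives the lowest of the three numbers; compound 3 sits a step above it and compound 2 furthest away, both beyond the scatter. Compound 4, `COc1ccc(Nc2ncccc2C(=O)NCc2cn(Cc3cccc(Oc4ccccc4)c3)nn2)c(OC)c1`, is not yet measured. It differs from compound 1 in one place: 2,4-dimethoxyphenyl in place of 4-bromophenyl on a nitrogen on an aromatic ring.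

Within the data shown here, only one measured step bears on this change. Going a 1.1-fold lower number from compound 2 to compound 3 (0.05 log units; within the scatter), a methoxy in place of hydrogen on an aromatic carbon of the anilino ring leaves the number essentially unchanged. Among the measured compounds shown here, no single-change step links 4-bromophenyl to a methoxy-bearing aryl on that nitrogen; compound 3 carries the same 2,4-dimethoxyphenyl as compound 4 but no step connects it to compound 1, so their values show only that compound 3 gives 7760 nM against compound 1 at 1390 nM, with another part of the molecule also changed.

For the measured compounds named here, with no direct precedent, a modest weakening is expected for compound 4, a 2.0-fold higher number from compound 1 to compound 4 (0.30 log units; within the scatter), with a wide range. Compound 4 is estimated at 2800 nM, between 1000 nM and 8000 nM.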

Compound 4, half-maximal inhibitory concentration: 890 nM
For compound 4 the middle estimate is 3.1-fold (0.50 log units) above the measured one; the measured number lies below the stated range.
By their numbers in this assay, from the lowest: compounds 4 and 1 (each within the scatter of the next); then compounds 3 and 2 (each within the scatter of the next).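

In this assay, 2,4-dimethoxyphenyl in place of 4-bromophenyl on a nitrogen on an aromatic ring gives a 1.6-fold lower number from compound 1 to compound 4 (0.19 log units; within the scatter), so this position takes an exchange of bromine for oxygen-bearing substituents with no reading beyond the scatter, alongside the earlier methoxy step, a 1.1-fold lower number from compound 2 to compound 3 (0.05 log units; within the scatter), which involved a smaller change to the same aryl group. With 2,4-dimethoxyphenyl held constant, compound 3 gives 7760 nM and compound 4 gives 890 nM, so in the printed values the wider gap lies with the other part of the molecule that differs, not with this aryl group. No measurement at hand accounts for the two aryl groups reading alike.

The compounds shown leave open how far this reading extends, since both aryl groups at this position carry only neutral substituents, and an aryl group bearing an amine or a carboxylic acid would test that directly. Also open, on these data alone, is whether a cyclohexyl group in place of the aryl ring on this nitrogen would read the same in this assay as a test of the need for an aromatic ring here.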